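The source may report more compounds than this note shows. Statements on the series, on what has been measured and on what is new or still open speak of the compounds shown alone.

Three compounds have been measured in a physicochemical assay for solubility, read by nephelometry, measured as kinetic solubility, at pH 2.0; on this read-out higher numbers stand for higher solubility and lower numbers for lower solubility:

- compound 1 `NCc1csc(NC(=O)c2ncccn2)n1`: > 100 ug/mL (a limit of the assay)
- compound 2 `CC(=O)NCc1csc(NC(=O)c2cc(C(C)(C)C)nn2Cc2ccccc2)n1`: 12.5 ug/mL
- compound 3 `NCc1csc(NC(=O)c2cnnn2Cc2ccccc2)n1`: > 100 ug/mL (a limit of the assay)

Only compound 2 has an actual number in this assay, at 12.5 ug/mL. The other two results give no number, only (the limit of > 100 ug/mL in this assay, at which 2 of the 3 values shown sit). Compound 2 therefore lies under that limit, but how far it lies from the true values of the other two compounds cannot be told.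

The next compound to be tested is compound 4 `CC(C)(C)c1cc(C(=O)Nc2nc(CNS(C)(=O)=O)cs2)n(Cc2ccccc2)n1`, which is compound 2 with one change: methylsulfonyl in place of acetyl on an amine nitrogen. In words, methylsulfonyl stands in place of acetyl on an amine nitrogen, so acetamidomethyl becomes (methanesulfonamido)methyl, and the rest of the molecule stays the same.

Among the measured compounds shown here, no pair of measured compounds differs in a single place, so the data offer no measured step to serve as a guide. The expectation therefore starts from compound 2 at 12.5 ug/mL, with no step beyond the scatter in either direction. The expected change is a 1.1-fold lower number from compound 2 to compound 4 (0.06 log units; within the scatter). For compound 4 the estimated value is 11 ug/mL. The expected range for compound 4 runs from 4 ug/mL to 32 ug/mL.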

Compound 4, solubility: 3.1 ug/mL
Beside the measured number, compound 4's estimate is 3.5-fold (0.55 log units) above it; measured number outside the range, below it.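

In this assay, among the compounds shown here, this is the first measured step at this place, the amine nitrogen whose other neighbour is a saturated chain carbon: a 4.0-fold lower number from compound 2 to compound 4 (0.61 log units; beyond the scatter). For the compounds shown here, exchanging acetyl for methylsulfonyl there, with the rest of the molecule unchanged, therefore moves the read-out beyond the usual scatter, which no earlier pair could show, as no two of the earlier compounds differed in a single place. The data shown give no measured property of either group that would account for the step.

As far as these compounds go, this single pair describes one exchange on one core, so it remains open whether the step would hold on another core, and where a longer acyl chain such as propanoyl, a urea or a carboxylic acid at the same nitrogen would fall relative to acetyl and methylsulfonyl. Compound 1 and compound 3 add no number against which this pair could be placed, as their results are limits of the assay: the limit of > 100 ug/mL in this assay, at which 2 of the 4 values shown sit.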